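Two benzyl variants measured, a third awaited

A few compounds are considered here, and "the series" means these few. Any claim that something is new, unique, unknown or untested is made for them only; others in the source may bear on it.

Compounds measured so far:
- Compound 1, `O=c1c2cnn(-c3ccc(F)cc3)c2ncn1CC1(O)CCN(Cc2ccc(Cl)cc2)CC1`: 8000 nM
- Compound 2, `O=c1c2cnn(-c3ccc(F)cc3)c2ncn1CC1(O)CCN(Cc2ccccc2Br)CC1`: 3100 nM
- Compound 3, `COC(=O)c1cccc(CN2CCC(O)(Cn3cnc4c(cnn4-c4ccc(F)cc4)c3=O)CC2)c1`: "not determined" (no result reported)

All three share one core and differ only in the aryl group on a saturated chain carbon bound to an amine nitrogen in a ring. In an assay on Sf21 cells for inhibition of ubiquitin carboxyl-terminal hydrolase 7 (Homo sapiens), read by spectrophotometry, with stated times of 30 min and 2 h (a lower number here means a stronger inhibitor, a higher number a weaker inhibitor), compound 1 gives 8000 nM, and compound 2 gives 3100 nM. The step of a 2.6-fold lower number from compound 1 to compound 2 (0.41 log units; beyond the scatter) is modest but beyond the scatter. As far as these compounds go, compound 3 stands nowhere on the numbers: for compound 3 the entry in this assay reads "not determined" (no result reported), so its place relative to compounds 1 and 2 is unknown.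

Compound 4, `N#Cc1cc(Cl)ccc1CN1CCC(O)(Cn2cnc3c(cnn3-c3ccc(F)cc3)c2=O)CC1`, has not yet been measured. Its structural change from compound 3 is 4-chloro-2-cyanophenyl in place of 3-(methoxycarbonyl)phenyl on a saturated chain carbon bound to an amine nitrogen in a ring.

Among the compounds with values here, only one measured step, from compound 1 to compound 2, concerns a change on the same aryl group, and it was modest. Compound 3 has no number to start from, so the expectation for compound 4 rests on the range spanned by compounds 1 and 2. Compound 4 is expected to give an inhibitory concentration of about 3500 nM in this assay, in the range 900 nM to 14000 nM, with no direction of change from compound 3 stated.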

Compound 4, half-maximal inhibitory concentration: 11400 nM
Beside the measured number, compound 4's estimate is 3.3-fold (0.51 log units) below it; the range from low to high includes it.
By their numbers in this assay, from the lowest: compound 2; then compounds 1 and 4 (each within the scatter of the next).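

In this assay, putting cyano in place of hydrogen on an aromatic carbon of the 4-chlorophenyl group gives a 1.4-fold higher number from compound 1 to compound 4 (0.15 log units; within the scatter), so at this position the added nitrile leaves compound 4 indistinguishable from compound 1. The choice of aryl group can still be told apart from the numbers: 4-chloro-2-cyanophenyl in place of 2-bromophenyl gives a 3.7-fold higher number from compound 2 to compound 4 (0.57 log units; beyond the scatter), and with its steps to both others beyond the scatter, compound 2 is the strongest of the three compounds with numbers. Nothing available explains why these aryl groups differ or why the nitrile leaves the number where it stands.

As far as these compounds go, compound 3 has no number, so the step to compound 4 cannot be read, and where the 3-(methoxycarbonyl)phenyl group stands among the others remains unknown. The compounds shown also leave open how a phenyl group carrying a carboxylic acid or an amine would fare, and what a longer chain in place of the saturated chain carbon bound to the ring amine nitrogen would do.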